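The compounds below may be only part of what the source reports. "The series", "measured", "known", "first", "only" and "open" are said of these compounds alone.

Measured so far:
compound 1 `Cc1cc(-c2ccc(F)cc2)c(S(C)(=O)=O)cc1C(=O)N=C(N)N`, 36 nM; compound 2 `Cc1cc(Sc2ccncc2)c(S(C)(=O)=O)cc1C(=O)N=C(N)N`, 13 nM; compound 3 `Cc1cc(N2CCC(N)CC2)c(S(C)(=O)=O)cc1C(=O)N=C(N)N`, 9.8 nM, all in a functional assay for inhibition of sodium/hydrogen exchanger (Oryctolagus cuniculus); on this read-out lower numbers stand for stronger inhibition and higher numbers for weaker inhibition.

Compound 3 has the lowest number of the three in this assay; against compound 2 the difference is a 1.3-fold lower number from compound 2 to compound 3 (0.12 log units; within the scatter), against compound 1 it is a 3.7-fold lower number from compound 1 to compound 3 (0.57 log units; beyond the scatter). Compound 4 `Cc1cc(C#N)c(S(C)(=O)=O)cc1C(=O)N=C(N)N` differs from compound 3 by one change: cyano in place of 4-aminopiperidin-1-yl on an aromatic carbon. Among the compounds with values here, no measured step swaps a ring for a group this small, so only the two steps at this position, a 2.8-fold lower number from compound 1 to compound 2 (0.44 log units; beyond the scatter) and a 3.7-fold lower number from compound 1 to compound 3 (0.57 log units; beyond the scatter), give a sense of its sensitivity, and both were modest. A modest step to a higher number, a 3.1-fold higher number from compound 3 to compound 4 (0.49 log units; beyond the scatter), is therefore expected for compound 4, with wide uncertainty. Compound 4 is estimated at 30 nM, within 8 nM to 120 nM.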

Compound 4, half-maximal inhibitory concentration: 70 nM
Beside the measured number, compound 4's estimate is 2.3-fold (0.37 log units) below it; the range from low to high includes it.
By their numbers in this assay, from the lowest: compounds 3 and 2 (each within the scatter of the next); then compounds 1 and 4 (each within the scatter of the next).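

In this assay, within the data shown here, cyano, the only group at this position without a ring, gives a 7.1-fold higher number from compound 3 to compound 4 (0.85 log units; beyond the scatter) and a 5.4-fold higher number from compound 2 to compound 4 (0.73 log units; beyond the scatter) while a 1.9-fold higher number from compound 1 to compound 4 (0.29 log units; within the scatter) is the one step of the three that stays inside the usual scatter. A ring at this position therefore does not by itself bring a lower number, since compound 1 with its 4-fluorophenyl and ringless compound 4 cannot be told apart.

Going by these compounds, whether the amine of 4-aminopiperidin-1-yl matters stays open, and plain piperidin-1-yl or an open chain ending in an amine would separate it from the ring. Nothing measured here accounts for these differences.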